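Fluorine on the aryl ring: lipophilicity of compound 4

A few compounds are considered here, and "the series" means these few. Any claim that something is new, unique, unknown or untested is made for them only; others in the source may bear on it.

Measured compounds:
compound 1 `O=C(Nc1ccc(C(F)(F)F)cc1)NC1CCN(C(=O)C2=COCC2)CC1` gives 3.37
compound 2 `CCC(=O)N1CCC(NC(=O)Nc2ccc(C(F)(F)F)c(F)c2)CC1` gives 3.76
compound 3 `O=C(Nc1ccc(C(F)(F)F)cc1)NC1CCN(C(=O)C2CCOCC2)CC1` gives 3.16

In a physicochemical assay for lipophilicity, read by HPLC, with a stated time of 90 min, tested at 100 uM (on this read-out lower numbers stand for lower lipophilicity and higher numbers for higher lipophilicity), compound 3 stands lowest of the three numbers. Within the data shown here, its nearest neighbour is compound 1, whose value lies higher by an amount within the scatter; the step of a number 0.21 log units lower from compound 1 to compound 3 (within the scatter) is the only single-point change among the measured compounds. Compound 2 lies furthest from compound 3, and that gap is beyond the scatter.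

Compound 4 `O=C(Nc1ccc(C(F)(F)F)c(F)c1)NC1CCN(C(=O)C2CCOCC2)CC1` differs from compound 3 in one place: fluoro in place of hydrogen on an aromatic carbon. Among the measured compounds shown here, no measured pair isolates this change. Compound 2 also carries fluoro ortho to a trifluoromethyl group, but it differs from compound 1 and compound 3 in the group on the carbonyl carbon as well, so its higher value in this assay cannot be attributed to the fluoro alone. The step from compound 1 to compound 3 concerns a different position and does not bear on it.

For the measured compounds named here, with no direct precedent, compound 4 is expected to sit close to compound 3, with at most a small rise, estimated as a number 0.20 log units higher from compound 3 to compound 4 (within the scatter). Compound 4 is therefore estimated at 3.36, within the range 3.05 to 3.65.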

Compound 4, partition coefficient: 3.52
Beside the measured number, compound 4's estimate is 0.16 log units below it, within the range that was stated.
By their numbers in this assay, from the lowest: compounds 3, 1, 4 and 2 (each within the scatter of the next, the first and the last beyond it).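

In this assay, among these compounds, the change of hydrogen to fluoro on an aromatic carbon, ortho to a trifluoromethyl group, can now be read on its own for the first time: a number 0.36 log units higher from compound 3 to compound 4 (beyond the scatter) is a modest shift, but one that clears the scatter. With the fluoro present in both compounds, the exchange of ethyl for oxan-4-yl on the carbonyl carbon gives a number 0.24 log units lower from compound 2 to compound 4 (within the scatter) and stays within the scatter, so the group on the carbonyl carbon opens no readable gap between this pair. No available measurement accounts for the effect of the fluoro on this number.

Going by these compounds, this reading rests on a single pair with the oxan-4-yl group on the carbonyl carbon, so it remains open whether fluoro gives a step of like size alongside the group on the carbonyl carbon of compound 1. On these data alone, it also remains open what chloro, methyl or methoxy would give on the same aromatic carbon.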